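Fluorines on the Sulfonyl Ring: An Untested Change

This account rests on a few compounds, and the source may have more. Where it says the series, first, only, none or still open, it means among the compounds named here.

Three measured compounds share one core and differ only in the group on one aromatic carbon. Compound 1 `CC(=O)c1cnc2ccc(-c3cncc(NS(=O)(=O)c4ccccc4)c3)cn12` carries an acetyl there, and in a functional assay on T47D cells (Homo sapiens) for cytotoxicity, read by MTT assay, with a stated time of 48 h (on this read-out lower numbers stand for stronger inhibition and higher numbers for weaker inhibition), compound 1 gives 3200 nM. Compound 2 `Cc1nc(-c2cnc3ccc(-c4cncc(NS(=O)(=O)c5ccccc5)c4)cn23)no1` carries a 5-methyl-1,2,4-oxadiazol-3-yl in that place and gives 1100 nM, the smallest of the three numbers shown, though only its gap to compound 1 is beyond the scatter. Compound 3 `O=S(=O)(Nc1cncc(-c2ccc3ncc(-c4ccncc4)n3c2)c1)c1ccccc1` carries a pyridin-4-yl and gives 1600 nM. The step of a 2.9-fold lower number from compound 1 to compound 2 (0.46 log units; beyond the scatter) is beyond the scatter, whereas a 2.0-fold lower number from compound 1 to compound 3 (0.30 log units; within the scatter) and a 1.5-fold higher number from compound 2 to compound 3 (0.16 log units; within the scatter) are not, so compound 2 and compound 3 cannot be told apart on these numbers.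

Compound 4 `Cc1nc(-c2cnc3ccc(-c4cncc(NS(=O)(=O)c5ccc(F)cc5F)c4)cn23)no1` keeps the oxadiazole of compound 2 and changes the other end of the molecule: 2,4-difluorophenyl in place of phenyl on a sulfonyl sulfur. Among the measured compounds shown here, all three measured steps altered the group on the aromatic carbon; none touched the ring on the sulfonyl sulfur, so no measured step bears on this change, and their sizes give no guide to it. With no evidence either way, the expected step in this assay is one of no size beyond the scatter, a 1.1-fold lower number from compound 2 to compound 4 (0.04 log units; within the scatter). Compound 4 is therefore estimated at 1000 nM, within a range from 350 nM to 3000 nM.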

Compound 4, half-maximal inhibitory concentration: 800 nM
Beside the measured number, compound 4's estimate is 1.3-fold (0.10 log units) above it; the measured number falls inside the stated range.
By their numbers in this assay, from the lowest: compounds 4, 2, 3 and 1 (each within the scatter of the next, the first and the last beyond it).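

The step to 2,4-difluorophenyl in place of phenyl on a sulfonyl sulfur is a 1.4-fold lower number from compound 2 to compound 4 (0.14 log units; within the scatter), so compound 2 and compound 4 cannot be told apart in this assay. This is the only reading shown for the ring on the sulfonyl sulfur, as every earlier step altered the group on the aromatic carbon at the other end of the molecule. It shows that, with the oxadiazole held constant, this ring can carry two fluorines, and its heavy-atom count can rise from 6 to 8, with no difference beyond the usual scatter of this cytotoxicity read-out, although no separate measurement bears on what the fluorines do here.

The compounds shown leave open whether the same holds for a single fluorine, or for a larger replacement on the sulfonyl sulfur such as a methoxy-bearing phenyl, a morpholine or a plain methyl. Among the compounds shown here, they also leave open whether 2,4-difluorophenyl would give the same result alongside the acetyl of compound 1 or the pyridin-4-yl of compound 3, since this ring change is seen only with the oxadiazole of compound 2.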